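A few compounds are considered here, and "the series" means these few. Any claim that something is new, unique, unknown or untested is made for them only; others in the source may bear on it.

Measured so far:
- Compound 1 `CC(C(=O)NCc1ccc(C(F)(F)F)nc1NCC1CCN(C(=O)OC(C)(C)C)CC1)c1ccc(NS(C)(=O)=O)c(F)c1`: 19.3 nM
- Compound 2 `Cc1ccc(Cl)cc1Nc1nc(C(F)(F)F)ccc1CNC(=O)C(C)c1ccc(NS(C)(=O)=O)c(F)c1`: 14 nM
- Compound 3 `C[C@H](C(=O)NCc1ccc(C(F)(F)F)nc1N1CC[C@@H](OCc2ccccc2)C1)c1ccc(NS(C)(=O)=O)c(F)c1`: 1.4 nM

In a functional assay on CHO-K1 cells for antagonist activity at transient receptor potential cation channel subfamily V member 1 (Homo sapiens), read by FLIPR (on this read-out higher numbers stand for weaker inhibition and lower numbers for stronger inhibition), compound 2 gives 14 nM. Compound 1 sits close by, within the usual scatter, while compound 3 gives a lower number, a gap beyond the scatter. Compound 4 `CC(C(=O)NCc1ccc(C(F)(F)F)nc1N1CCC(C)(C)CC1)c1ccc(NS(C)(=O)=O)c(F)c1` has not yet been measured. It differs from compound 2 in one place: 4,4-dimethylpiperidin-1-yl in place of (5-chloro-2-methylphenyl)amino on an aromatic carbon. Among the compounds with values here, no measured pair shows this exact change, so the step from compound 2 to compound 4 can only be guessed. Because compound 3, which also carries a ring amine on the shared core, gives 1.4 nM, a moderate move toward a lower number is expected, a 2.8-fold lower number from compound 2 to compound 4 (0.45 log units; beyond the scatter). Compound 4 is estimated at 5 nM, likely between 1.5 nM and 20 nM.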

Compound 4, inhibition constant: 0.3 nM
The estimate for compound 4 lay 17-fold (1.22 log units) above the measured number; measured number outside the range, below it.
By their numbers in this assay, from the lowest: compound 4; then compound 3; then compounds 2 and 1 (each within the scatter of the next).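

In this assay there is a 47-fold lower number from compound 2 to compound 4 (1.67 log units; beyond the scatter) when 4,4-dimethylpiperidin-1-yl replaces (5-chloro-2-methylphenyl)amino. Strong inhibition therefore does not require an aromatic ring or a hydrogen-bond donor in the group on this carbon, next to the ring nitrogen. No measurement here explains the size of this step. The compounds shown leave open whether the two methyl groups matter. An unsubstituted piperidin-1-yl or a morpholin-4-yl group on the same carbon would help separate the role of the ring from that of its methyl groups.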